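The source may report more compounds than this note shows. Statements on the series, on what has been measured and on what is new or still open speak of the compounds shown alone.

The series shares one core, shown in compound 1 `Cc1ccc(-c2cs/c(=N/NC(=O)CSc3nnnn3-c3ccccc3)n2-c2ccccc2)cc1`, compound 2 `Cn1cnnc1SCC(=O)N/N=c1/scc(-c2ccc([N+](=O)[O-])cc2)n1-c1ccccc1` and compound 3 `Cc1ccc(-c2cs/c(=N/NC(=O)CSc3nncn3C)n2-c2ccccc2)cc1`. Among the compounds with values here, in a functional assay on C6 cells (Rattus norvegicus) for cytotoxicity, read by MTT assay, with a stated time of 24 h (a lower number here means a stronger inhibitor, a higher number a weaker inhibitor), compound 1 gives 14.7 ug/mL, and this is the only number the set holds. For compound 2 the entry in this assay reads "not determined" (no result reported), so it stands nowhere on the scale; nothing can be said about how it compares with compound 1.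

The step from compound 2 to compound 3 is a single change on the aryl ring: methyl in place of nitro on an aromatic carbon. Within the data shown here, since compound 2 carries no value, there is no measured step to place this change against, and no pair in the set shows the same change elsewhere. Among the measured compounds shown here, the expectation for compound 3 therefore rests on compound 1, the one compound with a number, and the size and direction of any shift beyond the scatter cannot be stated; a difference within the scatter of compound 1 is the plainest assumption. On that basis compound 3 is estimated to give about 15 ug/mL in this assay, with a range from 6 ug/mL to 40 ug/mL.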

Compound 3, half-maximal inhibitory concentration: 56 ug/mL
Compound 3: the middle estimate sits 3.7-fold (0.57 log units) below what was measured; the measured number lies above the stated range.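

In this assay, within the data shown here, the one comparison that can be read lies not on the aryl ring but on the sulfur: with the 4-methylphenyl kept, 4-methyl-4H-1,2,4-triazol-3-yl in place of 1-phenyl-1H-tetrazol-5-yl gives a 3.8-fold higher number from compound 1 to compound 3 (0.58 log units; beyond the scatter), a weaker result beyond the scatter, so the group on the sulfur does move this number. The step from 4-nitrophenyl to 4-methylphenyl cannot be read, as compound 2 has no value, and the aryl position therefore remains without any measured effect. Nothing in the data available here bears on why the number rises with this change on the sulfur.

The step from compound 1 to compound 3 replaces the ring and its substituent together, so the compounds shown leave open whether the phenyl alone accounts for the shift, which a 1-methyl-1H-tetrazol-5-yl group on the sulfur would separate. They also leave open how a 4-aminophenyl or a 4-methoxyphenyl group would stand against the 4-methylphenyl on the shared core.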